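Aryl substituent change at the hydrazone of the series

The source may report more compounds than this note shows. Statements on the series, on what has been measured and on what is new or still open speak of the compounds shown alone.

The shared core carries an aryl hydrazone. Compound 1 `CC1CC/C(=N\Nc2cccc(Cl)c2)c2ncc(C(=O)O)c(=O)n21` gives in a functional assay on the whole organism for inhibition, with Rattus norvegicus as the target (a higher number here means that more compound is needed for the effect, a lower number that less compound is needed), only a limit, > 100 umol/kg. Compound 2 `CC1CC/C(=N\Nc2cccc(I)c2)c2ncc(C(=O)O)c(=O)n21` gives 1000 umol/kg, and compound 3 `COc1ccc(N/N=C2\CCC(C)n3c2ncc(C(=O)O)c3=O)cc1` gives 7.6 umol/kg, the lowest number shown; the nearest number is reached by a 130-fold lower number from compound 2 to compound 3 (2.12 log units; beyond the scatter), and an at least 13-fold lower number from compound 1 to compound 3 (1.11 log units; beyond the scatter) points the same way. Compound 4 `CC(C)c1ccc(N/N=C2\CCC(C)n3c2ncc(C(=O)O)c3=O)cc1` differs from compound 3 by isopropyl in place of methoxy on an aromatic carbon. Going by the values given here, no measured step varies the group para to a large group while keeping the ring otherwise unchanged; the two steps to compound 3 each replace 3-chlorophenyl or 3-iodophenyl with 4-methoxyphenyl and so do not read directly on this change. Little beyond the scatter is therefore expected in this assay: for compound 4 the expected step is a 2.0-fold higher number from compound 3 to compound 4 (0.30 log units; within the scatter). Compound 4 is estimated at 15 umol/kg, within 4 umol/kg to 60 umol/kg.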

Compound 4, dose for 50% inhibition: > 100 umol/kg
Compound 4: only a limit was reported; the forecaster's own chance of this, stated with the estimate: 10%; at least 6.6-fold (0.82 log units) between middle value and limit.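

Isopropyl in place of methoxy, on an aromatic carbon para to a large group, gives in this assay an at least 13-fold higher number from compound 3 to compound 4 (1.11 log units; beyond the scatter). The earlier steps shown here each exchanged the whole aryl group, whereas this one shows that the number depends on the group at this single position. Compound 4 gives > 100 umol/kg, which is a limit, so the step has only a lower bound: the limit of > 100 umol/kg in this assay, at which 2 of the 4 values shown sit.

As far as these compounds go, whether a hydroxyl, an amine or an ethyl at this place would stay close to compound 3 remains open. Also open, from the compounds shown here alone, is how far the number would rise with a readable value in place of the limit.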